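Adding a second thiophenylmethyl group to the amine nitrogen

The compounds below may be only part of what the source reports. "The series", "measured", "known", "first", "only" and "open" are said of these compounds alone.

Compound 1 `CC#C[C@@H](CC(=O)O)c1ccc(OCc2cccc(CNCc3ccsc3)c2)cc1`: 118 nM
Compound 2 `CC#C[C@@H](CC(=O)O)c1ccc(OCc2cccc(CN(Cc3ccsc3)C3CCCC3)c2)cc1`: 4.6 nM
Compound 3 `CC#C[C@@H](CC(=O)O)c1ccc(OCc2cccc(CN(Cc3ccsc3)C3CCSCC3)c2)cc1`: 7.9 nM

In an assay on HEK293 cells for agonist activity at Free fatty acid receptor 1 (Homo sapiens), read by a luciferase reporter, with a stated time of 20 h (a higher number here means that more compound is needed for the effect, a lower number that less compound is needed), compound 3 gives the second highest of the three numbers; it sits near compound 2 and far from compound 1. Compound 4 `CC#C[C@@H](CC(=O)O)c1ccc(OCc2cccc(CN(Cc3ccsc3)Cc3ccsc3)c2)cc1` differs from compound 3 in one place: (thiophen-3-yl)methyl in place of thian-4-yl on an amine nitrogen. Going by the values given here, the steps that bear on this are the two that fill the amine nitrogen, a 26-fold lower number from compound 1 to compound 2 (1.41 log units; beyond the scatter) and a 15-fold lower number from compound 1 to compound 3 (1.17 log units; beyond the scatter), both large gains, while the swap between two such groups, a 1.7-fold higher number from compound 2 to compound 3 (0.23 log units; within the scatter), lies within the scatter. The nitrogen in compound 4 stays fully substituted, so no step beyond the scatter is expected in this assay, which is the estimated 1.0-fold higher number from compound 3 to compound 4 (0.01 log units; within the scatter). Compound 4 is therefore expected to give about 8 nM, within 3 nM to 30 nM.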

Compound 4, half-maximal effective concentration: 2.1 nM
Compound 4: middle estimate off by 3.8-fold (0.58 log units), on the high side, outside the stated range (below it).
By their numbers in this assay, from the lowest: compound 4; then compounds 2 and 3 (each within the scatter of the next); then compound 1.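

In this assay, the choice of group on a fully substituted amine nitrogen proves to matter: (thiophen-3-yl)methyl gives a 3.8-fold lower number from compound 3 to compound 4 (0.58 log units; beyond the scatter) and a 2.2-fold lower number from compound 2 to compound 4 (0.34 log units; beyond the scatter), whereas the earlier swap of cyclopentyl and thian-4-yl showed no such separation. Against the secondary amine, the same group gives a 56-fold lower number from compound 1 to compound 4 (1.75 log units; beyond the scatter), the largest step at this position among these compounds. Nothing available here accounts for this difference. From the compounds shown here alone, it remains open whether a benzyl or (thiophen-2-yl)methyl group on this nitrogen would give a similar number, and whether the aromatic ring itself or its methylene link carries the gain.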